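An Acetyl Group on a Compound at the Limit

This account rests on a few compounds, and the source may have more. Where it says the series, first, only, none or still open, it means among the compounds named here.

Of the compounds shown here, two sharing one core have been measured so far in a functional assay on ECa-109 cells (Homo sapiens) for cytotoxicity, read by MTT assay, with a stated time of 48 h (a higher number here means a weaker inhibitor, a lower number a stronger inhibitor), on cancer cells. Compound 1 `COc1ccc(-c2c[nH]c(=O)n2-c2cc(OC)c(OC)c(OC)c2)cc1OC` gives > 50000 nM here, which is a limit of the assay and not a number. Compound 2 `COc1ccc(-c2c[nH]c(=O)n2-c2cc(OC)c(OC)c(OC)c2)cc1[N+](=O)[O-]` gives > 50000 nM here, and this too is only a limit. The change of nitro in place of methoxy on an aromatic carbon is a step that the two limits leave unreadable from compound 1 to compound 2 and so offers no size to carry forward. All that the data show so far is the limit of > 50000 nM in this assay, at which 2 of the 2 values shown sit, and no true number for either compound.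

Compound 3 `COc1ccc(-c2cn(C(C)=O)c(=O)n2-c2cc(OC)c(OC)c(OC)c2)cc1[N+](=O)[O-]` differs from compound 2 by one change, acetyl in place of hydrogen on an aromatic nitrogen. For the measured compounds named here, no measured step touches that place, so neither a size nor a direction can be read across. Because the limit of > 50000 nM in this assay, at which 2 of the 2 values shown sit, holds for compound 2 and compound 1 alike, compound 3 is expected most likely to stay near that limit. The expected at least 1.6-fold lower number from compound 2 to compound 3 (0.22 log units; that floor lies within the scatter) is therefore a small, uncertain estimate in this assay with only a slight lean towards stronger inhibition. For compound 3 the estimated value is 30000 nM with an expected range from 3000 nM to 100000 nM overall.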

Compound 3, half-maximal inhibitory concentration: 30800 nM
Estimate against measurement, compound 3: 1.0-fold (0.01 log units) below, and the stated range covers the measured number.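

In this assay compound 3 gives 30800 nM, the only true number among the compounds shown, so this nitrogen is a place where a change can yield a readable value in this assay. Acetyl in place of hydrogen on an aromatic nitrogen gives an at least 1.6-fold lower number from compound 2 to compound 3 (0.21 log units; that floor lies within the scatter); this is a floor and not a size, so the real gap may be larger, but the data cannot say by how much. The other two compounds remain limits and give nothing to set this number against: the limit of > 50000 nM in this assay, at which 2 of the 3 values shown sit.

The compounds shown leave open whether another group on this nitrogen, such as a longer chain like propanoyl or a simple methyl, would give a lower number than acetyl does. They also leave open whether acetyl on the same nitrogen of compound 1, which carries methoxy where compound 3 carries nitro, would give a readable number, and whether an amine in place of that nitro would change the value of compound 3.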